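Replacing 2-methylprop-1-en-1-yl with ethynyl on a carbonyl carbon

This account rests on a few compounds, and the source may have more. Where it says the series, first, only, none or still open, it means among the compounds named here.

Two compounds have numbers so far in a functional assay on MGC-803 cells (Homo sapiens) for inhibition, read by MTT assay, with a stated time of 48 h; on this read-out higher numbers stand for weaker inhibition and lower numbers for stronger inhibition
Compound 1 `COCC(=O)N(Cc1ccc(OC)c(O)c1)c1cc(OC)c(OC)c(OC)c1` gives 79 nM
Compound 2 `COc1ccc(CN(C(=O)C=C(C)C)c2cc(OC)c(OC)c(OC)c2)cc1O` gives 320 nM

Compound 2 (at 320 nM) holds the higher of the two numbers. Compound 3 `C#CC(=O)N(Cc1ccc(OC)c(O)c1)c1cc(OC)c(OC)c(OC)c1` differs from it in one place ethynyl in place of 2-methylprop-1-en-1-yl on a carbonyl carbon and carries ethynyl in place of 2-methylprop-1-en-1-yl on a carbonyl carbon. Going by the values given here, one measured step bears on this place, the modest one a 4.1-fold higher number from compound 1 to compound 2 (0.61 log units; beyond the scatter) that lies beyond the scatter, where 2-methylprop-1-en-1-yl came in place of methoxymethyl. Among the compounds with values here, no compound with ethynyl there has a number yet, so the direction remains uncertain. Within the data shown here, a modest move back toward lower numbers, no larger than that step, is expected in this assay once 2-methylprop-1-en-1-yl leaves. The expected step is a 2.1-fold lower number from compound 2 to compound 3 (0.33 log units; beyond the scatter) and it points downward. The estimated value for compound 3 is 150 nM (expected range 30 nM to 700 nM).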

Compound 3, half-maximal inhibitory concentration: 170 nM
The estimate for compound 3 lay 1.1-fold (0.05 log units) below the measured number; measured number inside the range.
By their numbers in this assay, from the lowest: compound 1; then compounds 3 and 2 (each within the scatter of the next).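

In this assay, replacing 2-methylprop-1-en-1-yl with the smaller ethynyl on the carbonyl carbon gives a 1.9-fold lower number from compound 2 to compound 3 (0.27 log units; within the scatter), so this change does not separate the two groups. Methoxymethyl now stands apart from both of them, since the second comparison with it gives a 2.2-fold higher number from compound 1 to compound 3 (0.33 log units; beyond the scatter) and the earlier one with 2-methylprop-1-en-1-yl also lay beyond the scatter. Nothing available explains why this position responds in this way.

From the compounds shown here alone, it remains open whether the oxygen in methoxymethyl matters, which a plain propyl chain at the same place could test. Going by these compounds, it is also open whether an amine, a carboxylic acid or a longer ether chain on this carbonyl carbon would give a number near that of compound 1 or one nearer those of compound 2 and compound 3.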